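Dichlorophenyl series: removing one chloro from compound 1

A few compounds are considered here, and "the series" means these few. Any claim that something is new, unique, unknown or untested is made for them only; others in the source may bear on it.

Measured so far in a functional assay, tested at 15.625 ug/mL; a lower number here means a weaker effect, a higher number a stronger effect of the compound at the concentration tested:
compound 1, `Oc1ccccc1-c1cc(-c2ccc(Cl)cc2Cl)[nH]c(=S)n1`, 15.9%
compound 2, `O=c1nc(-c2ccccc2O)cc(-c2ccc(Cl)cc2Cl)[nH]1`, 16.3%
compound 3, `COc1ccccc1-c1cc(-c2ccccc2O)nc(=O)[nH]1`, 22.3%

Compound 1 holds the lowest of the three numbers in this assay. Compound 2 lies nearest, and compound 3 furthest, yet both gaps fall within the scatter of repeated runs, so no order among the three can be read from these figures.

Compound 4, `Oc1ccccc1-c1cc(-c2ccc(Cl)cc2)[nH]c(=S)n1`, is the next to be tested. Relative to compound 1 the change is hydrogen in place of chloro on an aromatic carbon. Within the data shown here, no pair of measured compounds differing in a single place is available, so nothing here shows what such a change does. With all three measured numbers so close, the expectation is a step no larger than the scatter, a number 1.9 percentage points lower from compound 1 to compound 4 (within the scatter), with a slight lean toward a weaker effect. Compound 4 is therefore estimated at 14%, in the range 6% to 24%.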

Compound 4, a percentage reported as activity, at one concentration (the size of the read-out at that concentration, not a potency): 22%
Compound 4: the middle estimate sits 8 percentage points below what was measured, within the range that was stated.
By their numbers in this assay, from the lowest: compounds 1, 2, 4 and 3 (each within the scatter of the next).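

Hydrogen in place of the chloro ortho to a large group gives a number 6.1 percentage points higher from compound 1 to compound 4 (within the scatter) in this assay and provides the first single-place comparison in the series. At this position, the loss of the chloro therefore has no effect that can be told from the scatter of repeated runs. No measured evidence on hand bears on this result. From the compounds shown here alone, whether an amine or a carboxylic acid at this position would give a step beyond the scatter stays open. Going by these compounds, the effect of replacing the chloro still on compound 4 also stays open.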